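Notes on a methylsulfonyl replacement

This account rests on a few compounds, and the source may have more. Where it says the series, first, only, none or still open, it means among the compounds named here.

Within the data shown here, in a functional assay on L1210 cells (Mus musculus) for inhibition (a lower number here means a stronger inhibitor, a higher number a weaker inhibitor), compound 1 `C[S+](=N)([O-])CCC(NC(=O)c1ccc(NCc2cnc3nc(N)nc(O)c3n2)cc1)C(=O)O` gives 190000 nM and compound 2 `CC[S+](=N)([O-])CCC(NC(=O)c1ccc(NCc2cnc3nc(N)nc(O)c3n2)cc1)C(=O)O` gives 220000 nM, so compound 1 stands level with the only other measured compound. That single step, a 1.2-fold higher number from compound 1 to compound 2 (0.06 log units; within the scatter), lies within the scatter, and it is a different change, so it offers only indirect guidance. Compound 3 `CS(=O)(=O)CCC(NC(=O)c1ccc(NCc2cnc3nc(N)nc(O)c3n2)cc1)C(=O)O` differs from compound 1 as follows: a group of 4 heavy atoms (1 carbon, 2 oxygen, 1 sulfur; no ring) in place of a group of 4 heavy atoms (1 carbon, 1 nitrogen, 1 oxygen, 1 sulfur; no ring), on a saturated chain carbon, three bonds along the chain from an amide-type nitrogen and a carbonyl carbon. No step beyond the scatter is expected, and the estimated step is a 1.1-fold higher number from compound 1 to compound 3 (0.02 log units; within the scatter). Compound 3 is expected at 200000 nM, with an estimated range of 90000 nM to 450000 nM.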

Compound 3, half-maximal inhibitory concentration: 390000 nM
Estimate against measurement, compound 3: 2.0-fold (0.29 log units) below; low and high end bracket the measured number.
By their numbers in this assay, from the lowest: compounds 1, 2 and 3 (each within the scatter of the next, the first and the last beyond it).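

In this assay, among these compounds, the methylsulfonyl group, on this saturated chain carbon, gives a 2.1-fold higher number from compound 1 to compound 3 (0.31 log units; beyond the scatter) and thus the first step at this position beyond the scatter, though a modest one. Among the compounds shown here, with the same group at the same place, the other comparison gives a 1.8-fold higher number from compound 2 to compound 3 (0.25 log units; within the scatter) and stays within the scatter, so the change registers against only one of the two neighbours. Nothing available accounts for this step.

As far as these compounds go, whether an amine, a carboxylic acid or a longer chain at this place would give a clearly lower number remains open.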